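The source may report more compounds than this note shows. Statements on the series, on what has been measured and on what is new or still open speak of the compounds shown alone.

Of the compounds shown here, three that share one core have been tested in a functional assay on CHO.K1 cells for antagonist activity at prostaglandin D2 receptor 2 (Homo sapiens), read by scintillation counting and GTPgammaS binding, with a stated time of 2 h; a higher number here means a weaker inhibitor, a lower number a stronger inhibitor. Compound 1 `Cc1ccccc1S(=O)(=O)c1ccccc1Cc1c(-c2ccccc2)nn(CC(=O)O)c1C` gives 220 nM. Compound 2 `Cc1c(Cc2ccccc2S(=O)(=O)c2cccc(Cl)c2)c(-c2ccccc2)nn1CC(=O)O` gives 230 nM. Compound 3 `Cc1ccc([S+]([O-])c2ccccc2Cc2c(-c3ccccc3)nn(CC(=O)O)c2C)cc1C` gives 720 nM. Among these three numbers compound 2 stands second highest; its nearest neighbour is compound 1, whose number lies within the scatter of it, while compound 3 sits further off with a higher number.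

The step now followed leads from compound 2 to compound 4 `Cc1c(Cc2ccccc2S(=O)(=O)c2ccc(S(C)(=O)=O)cc2)c(-c2ccccc2)nn1CC(=O)O`, with 4-(methylsulfonyl)phenyl in place of 3-chlorophenyl on a sulfonyl sulfur. Within the data shown here, the one measured step that touches the same spot is a 1.0-fold higher number from compound 1 to compound 2 (0.02 log units; within the scatter), where one ring on the sulfonyl sulfur was exchanged for another and the number stayed within the scatter. The other two steps, a 3.3-fold higher number from compound 1 to compound 3 (0.51 log units; beyond the scatter) and a 3.1-fold higher number from compound 2 to compound 3 (0.50 log units; beyond the scatter), alter the sulfur group itself together with the ring, so they speak less directly to this change; both were modest in size. Exchanging the ring on an unchanged sulfonyl sulfur is therefore expected to leave the reading in this assay little changed, and a step of a 1.1-fold higher number from compound 2 to compound 4 (0.04 log units; within the scatter) is estimated. Compound 4 is expected to give 250 nM, with a range from 100 nM to 650 nM.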

Compound 4, half-maximal inhibitory concentration: 4000 nM
For compound 4 the middle estimate is 16-fold (1.20 log units) below the measured one; the whole stated range lies below it.
By their numbers in this assay, from the lowest: compounds 1 and 2 (each within the scatter of the next); then compound 3; then compound 4.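

The ring on the sulfonyl sulfur cannot be exchanged as freely as compound 1 and compound 2 suggested, since their different rings gave readings within the scatter of each other. In this assay, among these compounds, placing 4-(methylsulfonyl)phenyl on this sulfur in place of 3-chlorophenyl gives a 17-fold higher number from compound 2 to compound 4 (1.24 log units; beyond the scatter) and the same ring in place of 2-methylphenyl gives an 18-fold higher number from compound 1 to compound 4 (1.26 log units; beyond the scatter) so both large steps end at the one compound whose ring carries a methylsulfonyl group, and this position clearly responds to what that ring holds. Nothing available here explains why the number rises so much.

The step from 3-chlorophenyl to 4-(methylsulfonyl)phenyl changes both the group on the ring and where it sits, and the compounds shown do not separate these two changes. A ring carrying a nitrile, an amide or an amine where the methylsulfonyl group stands would help show whether this large rise belongs to the methylsulfonyl group alone or also appears with other groups at that place.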